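Chloro to heptylamino on the shared core: cytotoxicity notes

A few compounds are considered here, and "the series" means these few. Any claim that something is new, unique, unknown or untested is made for them only; others in the source may bear on it.

Compound 1, `CCCCNc1cncc(C(=O)NCc2ccccc2)n1`: > 100000 nM
Compound 2, `O=C(NCc1ccccc1)c1cncc(Cl)n1`: "not determined" (no result reported)

In an ADME assay on HEL cells (Homo sapiens) for cytotoxicity, read by microscopy, with a stated time of 6 days (a higher number here means that more compound is tolerated, a lower number that less compound is tolerated), compound 1 gives > 100000 nM, which is a limit of the assay and not a number. For the measured compounds named here, compound 2 has no result in this assay, so it stands on no number of its own; the one other value shown sits at the limit of > 100000 nM in this assay, at which 1 of the 2 values shown sits. Compound 3 is `CCCCCCCNc1cncc(C(=O)NCc2ccccc2)n1`, which differs from compound 2 by heptylamino in place of chloro on an aromatic carbon. Going by the values given here, no measured step exists to lean on, and in this assay nothing beyond the scatter is expected relative to compound 1. Compound 3 is estimated at 100000 nM, with a range from 20000 nM to 300000 nM.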

Compound 3, minimum cytotoxic concentration: > 100000 nM
Compound 3 ended at the assay's limit; the forecaster's own chance of this, stated with the estimate: 70%; the middle value sits exactly at the limit.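

No step from compound 1 to compound 3 can be read in this assay, as both values are limits of the assay: the limit of > 100000 nM in this assay, at which 2 of the 3 values shown sit.

The compounds shown leave open whether any chain on the shared core gives a readable minimum cytotoxic concentration.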